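The compounds below may be only part of what the source reports. "The series", "measured", "known", "first", "only" and "open" are said of these compounds alone.

The shared core of compound 1, whose structure is `Cc1ccc(NC2=CC(=O)c3nc4n(c3C2=O)[C@H]2OC[C@@H](O)[C@H]2OC4)cc1`, carries a (4-methylphenyl)amino group on the amine nitrogen. In a functional assay on HeLa cells (Homo sapiens) for inhibition, read by sulforhodamine B assay (on this read-out higher numbers stand for weaker inhibition and lower numbers for stronger inhibition), compound 1 gives 3860 nM, the only number shown on this read-out. Compound 2, with the structure `COc1cccc(NC2=CC(=O)c3c(nc4n3[C@H]3OC[C@@H](O)[C@H]3OC4)C2=O)c1`, carries a (3-methoxyphenyl)amino group on a core of differing arrangement, and in this assay compound 2 gives only a limit of > 8000 nM. This is the limit of > 8000 nM in this assay, at which 1 of the 2 values shown sits.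

Compound 3, with the structure `COc1cccc(NC2=CC(=O)c3nc4n(c3C2=O)[C@H]2OC[C@@H](O)[C@H]2OC4)c1`, has not yet been measured. Its difference from compound 1 is 3-methoxyphenyl in place of 4-methylphenyl on an amine nitrogen, the same difference, cut one bond further out, reading (4-methylphenyl)amino to (3-methoxyphenyl)amino. No measured step between two compounds differing in one place is shown, so the size of the change is uncertain. Compound 2 shows only a limit with the same entering group, so a step toward weaker inhibition, beyond the scatter, is expected from compound 1 to compound 3, namely a 1.9-fold higher number from compound 1 to compound 3 (0.29 log units; within the scatter). Compound 3 is therefore estimated to give 7500 nM in this assay, within a range from 3000 nM to 20000 nM.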

Compound 3, half-maximal inhibitory concentration: 4280 nM
Beside the measured number, compound 3's estimate is 1.8-fold (0.24 log units) above it, and the stated range covers the measured number.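

In this assay, putting 3-methoxyphenyl in place of 4-methylphenyl on the amine nitrogen gives a 1.1-fold higher number from compound 1 to compound 3 (0.04 log units; within the scatter), so compound 1 and compound 3 cannot be told apart on this read-out. Among these compounds, this is the first step that can be read at this position, and it shows that on the shared core of compound 1 the entering group, with its oxygen and its hydrogen-bond acceptor, brings no change beyond the scatter. Compound 2 carries the same (3-methoxyphenyl)amino group on a core of differing arrangement and remains a limit: the limit of > 8000 nM in this assay, at which 1 of the 3 values shown sits.

The single step changes both the substituent and its place on the phenyl ring, so the compounds shown do not separate the two, and a 4-methoxyphenyl or a 3-methylphenyl group would be needed to do so. They also leave open how this assay would respond to a chlorine atom, an amine or a carboxylic acid on that phenyl ring, or to a longer chain in place of the ring on the amine nitrogen.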